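From 4-chlorophenyl to 3-chloro-4-fluorophenyl on the sulfonamide

A few compounds are considered here, and "the series" means these few. Any claim that something is new, unique, unknown or untested is made for them only; others in the source may bear on it.

Among the measured compounds shown here, in a functional assay on Huh-7 cells (Homo sapiens) for inhibition, read by CCK-8 assay, with a stated time of 72 h (a higher number here means a weaker inhibitor, a lower number a stronger inhibitor), compound 1 `O=C(/C=C/c1cccnc1)NCCCCCCc1cccc(S(=O)(=O)Nc2ccccc2)c1` gives 2.82 nM, the lowest number measured so far. Compound 2 `CCc1ccc(NS(=O)(=O)c2cccc(CCCCCCNC(=O)/C=C/c3cccnc3)c2)cc1` gives 34.6 nM. Compound 3 `O=C(/C=C/c1cccnc1)NCCCCCCc1cccc(S(=O)(=O)Nc2ccc(Cl)cc2)c1` gives 24.1 nM. Compound 3 thus stands with compound 2 at the high end of the three numbers, the two lying within the scatter of each other and well above compound 1.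

Compound 4 `O=C(/C=C/c1cccnc1)NCCCCCCc1cccc(S(=O)(=O)Nc2ccc(F)c(Cl)c2)c1` carries 3-chloro-4-fluorophenyl in place of 4-chlorophenyl on a sulfonamide nitrogen. For the measured compounds named here, three measured steps bear on this change. Adding chloro gave an 8.5-fold higher number from compound 1 to compound 3 (0.93 log units; beyond the scatter), and ethyl in the same role gave a 12-fold higher number from compound 1 to compound 2 (1.09 log units; beyond the scatter). Exchanging one of these groups for the other gave a 1.4-fold lower number from compound 2 to compound 3 (0.16 log units; within the scatter), which stays within the scatter. The large rise therefore separates compound 1 from the two substituted compounds, while these two do not differ measurably. Going by the values given here, no measured compound carries fluoro or a second group on this ring, so the evidence is indirect. In this assay, no step beyond the scatter is expected, and the expected step is a 1.2-fold higher number from compound 3 to compound 4 (0.10 log units; within the scatter). The estimate for compound 4 is 30 nM, with an expected range from 9 nM to 90 nM.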

Compound 4, half-maximal inhibitory concentration: 39.4 nM
The estimate for compound 4 lay 1.3-fold (0.12 log units) below the measured number; the measured number falls inside the stated range.
By their numbers in this assay, from the lowest: compound 1; then compounds 3, 2 and 4 (each within the scatter of the next).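

In this assay, among the compounds shown here, 3-chloro-4-fluorophenyl in place of 4-chlorophenyl on a sulfonamide nitrogen gives a 1.6-fold higher number from compound 3 to compound 4 (0.21 log units; within the scatter) and, in place of 4-ethylphenyl at the same nitrogen, it gives a 1.1-fold higher number from compound 2 to compound 4 (0.06 log units; within the scatter) so compounds 2, 3 and 4 all lie within the scatter of one another, and the fluoro and the shifted chloro of compound 4 bring no step that can be read against either earlier ring. Against the plain phenyl, the same exchange gives a 14-fold higher number from compound 1 to compound 4 (1.15 log units; beyond the scatter) so a ring with two groups stands on the same high side as the rings with one, and among the four compounds shown every substituted ring lies well above compound 1, with none going against this. Nothing measured in the material shown gives a reason for this pattern.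

The compounds shown leave open whether fluoro alone on this ring would stay close to compound 1 or join compounds 2, 3 and 4. They also leave open how a methoxy group, an amine or a carboxylic acid on the same ring would read in this assay against the plain phenyl.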